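The source may report more compounds than this note shows. Statements on the series, on what has been measured and on what is new or still open speak of the compounds shown alone.

In an ADME assay on the whole organism (Mus musculus, strain CD-1) for pharmacokinetics, read by LC-MS, with a stated time of 7 h, at a dose of 10 mg/kg by the intraperitoneal route (on this read-out higher numbers stand for higher exposure at the dose given and lower numbers for lower exposure), compound 2 (`CC(Sc1nc2nn(C3COC3)cc2c(=O)n1-c1ccccc1)c1ccccc1`) gives 7890 ng.h/mL, the higher of the two numbers available, while compound 1 (`CC(Sc1nc2nn(C3COC3)cc2c(=O)n1-c1ccccc1)c1ccccn1`) gives 1420 ng.h/mL. For the measured compounds named here, the one measured step, a 5.6-fold higher number from compound 1 to compound 2 (0.74 log units; beyond the scatter), is beyond the scatter, but it concerns phenyl in place of pyridin-2-yl, a change at a different place in the molecule. Compound 3 (`CC(Sc1nc2nn(C3(C)COC3)cc2c(=O)n1-c1ccccc1)c1ccccc1`) differs from compound 2 by methyl in place of hydrogen on a saturated ring carbon, so that oxetan-3-yl becomes 3-methyloxetan-3-yl. Going by the values given here, no measured step covers this change, so the data give no direct guide to its size or direction in this assay. The expected outcome is therefore no shift beyond the scatter, with an estimated 1.2-fold lower number from compound 2 to compound 3 (0.08 log units; within the scatter). Compound 3 is estimated at 6500 ng.h/mL, with an expected range of 2500 ng.h/mL to 15000 ng.h/mL.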

Compound 3, area under the concentration-time curve: 9630 ng.h/mL
Beside the measured number, compound 3's estimate is 1.5-fold (0.17 log units) below it; low and high end bracket the measured number.
By their numbers in this assay, from the lowest: compound 1; then compounds 2 and 3 (each within the scatter of the next).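

Moving from oxetan-3-yl to 3-methyloxetan-3-yl gives the first reading at this position: in this assay the step is a 1.2-fold higher number from compound 2 to compound 3 (0.09 log units; within the scatter). One added methyl on this saturated ring carbon, two ring bonds from the ring oxygen, therefore produces no shift that can be told from the scatter, unlike the step at the other place in the molecule, a 5.6-fold higher number from compound 1 to compound 2 (0.74 log units; beyond the scatter). The data shown offer nothing that bears on the reason for this result.

The compounds shown leave open whether a larger or different group on this carbon, such as an ethyl group, an amine or a hydroxymethyl group, would also leave the number within the scatter. They also leave open whether the same methyl would read alike with the pyridin-2-yl group of compound 1 in place of phenyl.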